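A few compounds are considered here, and "the series" means these few. Any claim that something is new, unique, unknown or untested is made for them only; others in the source may bear on it.

The account concerns an assay on HEK293 cells for positive allosteric modulation of metabotropic glutamate receptor 2 (Rattus norvegicus), read by thallium flux; on this read-out lower numbers stand for an effect already at smaller amounts and higher numbers for an effect only at larger amounts of compound. Compound 1, `O=C1c2ccc(OCc3cccc(-c4ccc(Cl)cc4F)c3)cc2CN1C1CCCC1`, reaches only a boundary there. In this assay compound 1 gives > 5000 nM, which is a limit of the measurement and not a number, as recorded by the limit of > 5000 nM in this assay, at which 1 of the 3 values shown sits. Two further compounds carry the same ether-linked biaryl arm on a different core. Compound 2, `Cn1sc2cc(OCc3cccc(-c4ccc(Cl)c(C(=O)O)c4)c3)ccc2c1=O`, gives 640 nM in this assay. Compound 3, `CN(C)C(=O)c1cc(-c2cccc(COc3ccc4c(=O)n(C5CCCC5)sc4c3)c2)ccc1Cl`, gives 980 nM in this assay. Compound 4, `COc1ccc(C(=O)O)cc1-c1cccc(COc2ccc3c(c2)CN(C2CCCC2)C3=O)c1`, keeps the core of compound 1 and alters only the outer aryl group: 5-carboxy-2-methoxyphenyl in place of 4-chloro-2-fluorophenyl on an aromatic carbon. Within the data shown here, no pair of measured compounds differs in exactly this way, so the size of the change has no measured counterpart, and the two cores of compound 2 and compound 1 are not the same. Still, compound 4 is expected to give a number rather than a limit, because compound 2 gives 640 nM with a carboxy group on its outer ring. Compound 4 is estimated at 2000 nM in this assay, within a range from 500 nM to 8000 nM. That estimate means an expected step of an at least 2.5-fold lower number from compound 1 to compound 4 (0.39 log units; beyond the scatter) toward an effect at smaller amounts of compound, well beyond the usual scatter.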

Compound 4, half-maximal effective concentration: 80 nM
Compound 4: the middle estimate sits 25-fold (1.40 log units) above what was measured, and the stated range ends above it.
By their numbers in this assay, from the lowest: compound 4; then compounds 2 and 3 (each within the scatter of the next). At a limit, above all of these: compound 1.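

On this aromatic carbon, meta to a large group, the outer ring proves decisive for the read-out in this assay: with the core of compound 1 unchanged, putting 5-carboxy-2-methoxyphenyl in place of 4-chloro-2-fluorophenyl gives an at least 62-fold lower number from compound 1 to compound 4 (1.79 log units; beyond the scatter). Among these compounds, this is the first step that can be read across a single change, and it shows that a change confined to the outer aryl group is enough to turn a limit into a measured number on this core. The step is only a lower bound on the true size of the change, as compound 1 stands at a limit and not at a number: the limit of > 5000 nM in this assay, at which 1 of the 4 values shown sits.

From the compounds shown here alone, the step does not separate the carboxy group from the methoxy group, as both enter together while the chlorine and the fluorine leave together, so the share of each remains open. Nor do the compounds shown tell whether a primary amide, a nitrile or a tetrazole in place of the carboxylic acid, or an ethoxy group in place of the methoxy group, would keep a step of this size on the same core.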